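A few compounds are considered here, and "the series" means these few. Any claim that something is new, unique, unknown or untested is made for them only; others in the source may bear on it.

Of the compounds shown here, two share a core and have been measured. Compound 2 `c1ccc(Sc2c(-c3ccccc3)nc3ccc(-c4ccccc4)cn23)cc1` carries a phenyl group on the shared core, and in a functional assay on HeLa cells (Homo sapiens) for inhibition, read by MTT assay, with a stated time of 48 h (on this read-out lower numbers stand for stronger inhibition and higher numbers for weaker inhibition), compound 2 gives 72600 nM. Compound 1 `C(=C/c1nc2ccccn2c1Sc1ccccc1)\c1ccccc1` differs from it in more than one place, and in this assay compound 1 gives 35500 nM. Within the data shown here, of the two numbers, the one for compound 2 is the higher, meaning the weaker inhibition, and the gap between the two lies beyond the usual scatter. Among the measured compounds shown here, since the two structures differ in several places at once, no single structural step links them, and the comparison shows only that compound 2 stands at the weaker end of what has been measured.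

Compound 3 `Clc1ccc2nc(-c3ccccc3)c(Sc3ccccc3)n2c1` is not yet measured. It differs from compound 2 in one place: chloro in place of phenyl on an aromatic carbon. For the measured compounds named here, no measured pair shows what this exchange does, so its direction is open. Only a small step is expected, not clearly beyond the scatter either way, and the expected step is a 1.2-fold lower number from compound 2 to compound 3 (0.08 log units; within the scatter). Compound 3 is expected to give 60000 nM in this assay, with a range from 20000 nM to 180000 nM.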

Compound 3, half-maximal inhibitory concentration: 29300 nM
Compound 3: middle estimate off by 2.0-fold (0.31 log units), on the high side; low and high end bracket the measured number.
By their numbers in this assay, from the lowest: compounds 3 and 1 (each within the scatter of the next); then compound 2.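

Among these compounds, this is the first single change that can be read in this set: on this aromatic carbon, two atoms from the ring nitrogen, chloro in place of phenyl gives a 2.5-fold lower number from compound 2 to compound 3 (0.39 log units; beyond the scatter) in this assay, which means stronger inhibition. A whole six-membered aromatic ring of six carbons leaves and a single chlorine atom enters, so in this read-out the phenyl ring at this position is not needed for the inhibition seen, and losing it does not weaken the compound. Nothing measured here explains why the number falls, so the step stands as an observation without a known cause.

A single step also cannot separate two readings: the gain may come from the loss of the phenyl ring or from the arrival of the chlorine. As far as these compounds go, what a fluoro group, an amine or a carboxylic acid would do on this same carbon remains open, and so does whether the step would keep its direction on a different core.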